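This account rests on a few compounds, and the source may have more. Where it says the series, first, only, none or still open, it means among the compounds named here.

Measured so far in a functional assay on BV-2 cells (Mus musculus) for inhibition, read by Griess assay, with a stated time of 24 h; a lower number here means a stronger inhibitor, a higher number a weaker inhibitor:
Compound 1 `CCCc1cc(-c2cc(Br)ccc2OC)no1`: > 200000 nM
Compound 2 `CCOC(=O)COCc1cc(-c2cc(Br)ccc2OC)no1`: > 200000 nM

Compound 2 gives > 200000 nM, which is a limit of the assay and not a number. Among the measured compounds shown here, the one other value, for compound 1, is also a limit. Taken together, the measurements amount to the limit of > 200000 nM in this assay, at which 2 of the 2 values shown sit.

Compound 3 `COc1ccc(Br)cc1-c1cc(COCc2ccccc2)on1` is the next entry. The change from compound 2 is phenyl in place of ethoxycarbonyl on a saturated chain carbon bound to an oxygen on a saturated carbon. In words, this puts phenyl in place of ethoxycarbonyl on a saturated chain carbon bound to an oxygen on a saturated carbon, so that (ethoxycarbonyl)methyl becomes benzyl.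

For the measured compounds named here, only one measured step bears on this change, and it supplies no size to carry over. Because of a step that the two limits leave unreadable from compound 1 to compound 2 no step beyond the scatter is expected in this assay, and no direction can be predicted. The expected step is a number no higher from compound 2 to compound 3 (the limit leaves the size open). A further limit is the most likely outcome. If a number is reported, compound 3 is estimated at 200000 nM, with an expected range of 60000 nM to 400000 nM.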

Compound 3, half-maximal inhibitory concentration: > 200000 nM
Compound 3: only a limit was reported; the forecaster's own chance of this, stated with the estimate: 70%; the middle value sits exactly at the limit.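

Compound 3 gives > 200000 nM in this assay, which is a limit of the assay and not a number. No step can be read from compound 2 to compound 3 or among the other compounds, which stand at the same limit: the limit of > 200000 nM in this assay, at which 3 of the 3 values shown sit.

The compounds shown leave open how strongly any of them inhibits and whether the group on this chain matters in this assay.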